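Anilino Replaces Chlorophenoxy on a Sodium/Hydrogen Exchanger Inhibitor

A few compounds are considered here, and "the series" means these few. Any claim that something is new, unique, unknown or untested is made for them only; others in the source may bear on it.

Compound 3 `Cc1cc(Oc2ccc(Cl)cc2)c(S(C)(=O)=O)cc1C(=O)N=C(N)N` gives 13 nM in a functional assay for inhibition of sodium/hydrogen exchanger (Oryctolagus cuniculus) (a lower number here means a stronger inhibitor, a higher number a weaker inhibitor), the second highest of three numbers: compound 2 `CCCSc1cc(C)c(C(=O)N=C(N)N)cc1S(C)(=O)=O` gives 6.8 nM and compound 1 `Cc1cc(Cl)c(S(C)(=O)=O)cc1C(=O)N=C(N)N` gives 25 nM, each within the scatter of compound 3. Compound 4 `Cc1cc(Nc2ccccc2)c(S(C)(=O)=O)cc1C(=O)N=C(N)N` differs from compound 3 by anilino in place of 4-chlorophenoxy on an aromatic carbon. Two measured steps at this aromatic carbon bear on the change: a 1.9-fold lower number from compound 1 to compound 3 (0.28 log units; within the scatter) and a 1.9-fold higher number from compound 2 to compound 3 (0.28 log units; within the scatter), while a 3.7-fold lower number from compound 1 to compound 2 (0.57 log units; beyond the scatter). Chloro, propylsulfanyl and 4-chlorophenoxy therefore move this assay only modestly, and no step beyond the scatter is expected from anilino. The expected step is a 1.1-fold lower number from compound 3 to compound 4 (0.03 log units; within the scatter). Compound 4 is accordingly estimated to give 12 nM in this assay, with a range of 4 nM to 36 nM.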

Compound 4, half-maximal inhibitory concentration: 21 nM
Estimate against measurement, compound 4: 1.8-fold (0.24 log units) below, within the range that was stated.
By their numbers in this assay, from the lowest: compounds 2, 3, 4 and 1 (each within the scatter of the next, the first and the last beyond it).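

In this assay, anilino in place of 4-chlorophenoxy gives a 1.6-fold higher number from compound 3 to compound 4 (0.21 log units; within the scatter) and anilino in place of chloro gives a 1.2-fold lower number from compound 1 to compound 4 (0.08 log units; within the scatter), so at this carbon neither step passes the scatter, even though the swap for 4-chlorophenoxy adds a hydrogen-bond donor. For the compounds shown here, only the step from propylsulfanyl passes it, with a 3.1-fold higher number from compound 2 to compound 4 (0.49 log units; beyond the scatter), a modest change. Nothing available explains these steps. The compounds shown leave open whether 4-chloroanilino would behave like anilino, since the ring chlorine and the linking atom changed together here, and whether propylamino would match propylsulfanyl.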